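Swapping chloro for hydroxy on compound 2

A few compounds are considered here, and "the series" means these few. Any claim that something is new, unique, unknown or untested is made for them only; others in the source may bear on it.

Measured in an ADME assay on KB cells (Homo sapiens) for cytotoxicity; on this read-out higher numbers stand for an effect only at larger amounts of compound and lower numbers for an effect already at smaller amounts:
Compound 1 `Nc1nc(Cl)c2ncn(C3CC(O)C(CO)C3)c2n1` gives 62 ug/mL
Compound 2 `Nc1nc(Cl)c2nnn(C3CC(O)C(CO)C3)c2n1` gives 10 ug/mL
Compound 3 `Nc1nc(O)c2ncn([C@@H]3C[C@H](CO)[C@@H](O)C3)c2n1` gives 95 ug/mL

Compound 2 has the lowest number of the three in this assay, and both other compounds lie beyond the scatter from it. Compound 1 (62 ug/mL) and compound 3 (95 ug/mL) lie within the scatter of each other.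

The next compound to be tested is compound 4 `Nc1nc(O)c2nnn(C3CC(O)C(CO)C3)c2n1`, made from compound 2 by one change: hydroxy in place of chloro on an aromatic carbon. Hydroxy stands in place of chloro on an aromatic carbon. Going by the values given here, no measured pair shows this swap alone, so any forecast is uncertain. Among the compounds with values here, the one guide is compound 3, which carries hydroxy on a different core and gives a much higher number (95 ug/mL) than compound 2 (10 ug/mL). A moderate move to a higher number in this assay, beyond the scatter, is therefore expected, amounting to a 4.0-fold higher number from compound 2 to compound 4 (0.60 log units; beyond the scatter) as estimated. For compound 4 the estimated value is 40 ug/mL (expected range 12 ug/mL to 130 ug/mL).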

Compound 4, concentration for half-maximal effect: > 100 ug/mL
Compound 4 was reported as a limit; the forecaster's own chance of this, stated with the estimate: 20%; at least 2.5-fold (0.39 log units) between middle value and limit.
By their numbers in this assay, from the lowest: compound 2; then compounds 1 and 3 (each within the scatter of the next). At a limit, above all of these: compound 4.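

Going by these compounds alone, on the aromatic carbon next to the ring nitrogen, hydroxy in place of chloro gives an at least 10-fold higher number from compound 2 to compound 4 (1.00 log units; beyond the scatter) in this assay, and this pair is the first to show the swap alone, with a step beyond the scatter. Compound 4 gives > 100 ug/mL, which is a limit of the assay and not a number. The step is thus known from one side only, and its upper end remains unknown: the limit of > 100 ug/mL in this assay, at which 1 of the 4 values shown sits.

The compounds shown leave open whether hydroxy in place of chloro gives a similar step on the core of compound 1. They also leave open what an amine, a methoxy group or a thiol would give on this aromatic carbon, and so whether the step follows from the loss of chloro or from the entry of hydroxy.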